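Swapping a bromine for a pyrrole ring on the anilide

This account rests on a few compounds, and the source may have more. Where it says the series, first, only, none or still open, it means among the compounds named here.

Compound 1 `C[C@H](NC(=O)C(=O)NC1CCCCC1)C(=O)N[C@@H](CC(=O)O)C(=O)COc1c(F)c(F)cc(F)c1F`: 150 nM
Compound 2 `C[C@H](NC(=O)C(=O)Nc1ccccn1)C(=O)N[C@@H](CC(=O)O)C(=O)COc1c(F)c(F)cc(F)c1F`: 1040 nM
Compound 3 `C[C@H](NC(=O)C(=O)Nc1ccccc1Br)C(=O)N[C@@H](CC(=O)O)C(=O)COc1c(F)c(F)cc(F)c1F`: 75 nM

These three compounds share one core and differ only in the group on the outer amide nitrogen. In a functional assay on Jurkat cells (Homo sapiens) for inhibition (a lower number here means a stronger inhibitor, a higher number a weaker inhibitor), compound 3 gives the lowest number of the three. Its nearest neighbour is compound 1, and the step of a 2.0-fold lower number from compound 1 to compound 3 (0.30 log units; within the scatter) stays within the scatter. The step of a 14-fold lower number from compound 2 to compound 3 (1.14 log units; beyond the scatter) is large, while a 6.9-fold higher number from compound 1 to compound 2 (0.84 log units; beyond the scatter) is modest.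

Compound 4 `C[C@H](NC(=O)C(=O)Nc1ccccc1-c1ccc[nH]1)C(=O)N[C@@H](CC(=O)O)C(=O)COc1c(F)c(F)cc(F)c1F` keeps the phenyl ring of compound 3 and changes only one point: 1H-pyrrol-2-yl in place of bromo on an aromatic carbon. The new group sits on an aromatic carbon of a six-membered aromatic ring of carbon only, ortho to a large group.

Among the measured compounds shown here, no measured step exchanges the bromine for another group, so the three steps speak only indirectly. They show that an aromatic ring on the amide nitrogen is tolerated in compound 3, and that a ring with a nitrogen in compound 2 gave a higher number. The entering pyrrole carries a nitrogen as a hydrogen-bond donor, which leaves the direction open. Compound 4 is therefore expected to land near compound 3, with the step of a 1.5-fold higher number from compound 3 to compound 4 (0.17 log units; within the scatter) estimated as small. The estimate for compound 4 is 110 nM, with a range from 30 nM to 450 nM.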

Compound 4, half-maximal inhibitory concentration: 56 nM
Compound 4: middle estimate off by 2.0-fold (0.29 log units), on the high side; the measured number falls inside the stated range.
By their numbers in this assay, from the lowest: compounds 4, 3 and 1 (each within the scatter of the next, the first and the last beyond it); then compound 2.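

Exchanging the bromine for 1H-pyrrol-2-yl puts a ring of 5 heavy atoms and a hydrogen-bond donor in place of a single atom, yet the change stays within the scatter (a 1.3-fold lower number from compound 3 to compound 4 (0.13 log units; within the scatter)), so in this assay this aromatic carbon carries either group with no clear difference. The 2-(1H-pyrrol-2-yl)phenyl group also gives a step beyond the scatter against cyclohexyl (a 2.7-fold lower number from compound 1 to compound 4 (0.43 log units; beyond the scatter)), which 2-bromophenyl did not, and a large step against pyridin-2-yl (a 19-fold lower number from compound 2 to compound 4 (1.27 log units; beyond the scatter)). Nothing available explains why these numbers fall as they do.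

A 1-methylpyrrol-2-yl group on the same aromatic carbon would show whether the hydrogen on the pyrrole nitrogen matters. Going by these compounds, it also remains open how an amine or a methoxy group at that carbon would compare with bromo and 1H-pyrrol-2-yl.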